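The source may hold more compounds than are shown below. What is called first, only, known or untested is meant among the compounds shown, and "the series" means these compounds.

Measured so far:
compound 1, `COc1cc(NC(=S)Nc2cc(OC)c(OC)c(OC)c2)cc(OC)c1OC`: 31800 nM
compound 2, `O=C(O)c1ccc(NC(=S)NCc2ccccc2)cc1O`: 8100 nM
compound 3, `COc1ccc(NC(=S)NCc2ccccc2)cc1`: a limit, >= 200000 nM

In a functional assay on RAW264.7 cells (Mus musculus) for inhibition, read by Griess assay, with a stated time of 24 h (a higher number here means a weaker inhibitor, a lower number a stronger inhibitor), compound 2 gives 8100 nM, the lowest of the two numbers shown. Compound 1 gives 31800 nM, a higher number and a gap that lies beyond the usual scatter. For compound 3 only a limit is known, >= 200000 nM, so it carries no number to rank against the other two (the limit of >= 200000 nM in this assay, at which 1 of the 3 values shown sits).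

The next compound in the series is compound 4, `Oc1cccc(NC(=S)NCc2ccccc2)c1`. It differs from compound 2 in one place:
hydrogen in place of carboxy on an aromatic carbon
The hydroxy group and the benzyl-bearing thiourea are kept; only the carboxy group on the aromatic carbon is gone.

Among the measured compounds shown here, no step between measured compounds covers this change. Since compound 3, which lacks both the carboxy and the free hydroxy, gives only a limit, the carboxy is expected to contribute, and its loss is expected to move the number upward in this assay, by more than the scatter but not to the limit. For compound 4 the expected value is 40000 nM, within 12000 nM to 150000 nM, an expected step of a 4.9-fold higher number from compound 2 to compound 4 (0.69 log units; beyond the scatter).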

Compound 4, half-maximal inhibitory concentration: 200000 nM
Compound 4: the middle estimate sits 5.0-fold (0.70 log units) below what was measured; the measured number lies above the stated range.
By their numbers in this assay, from the lowest: compound 2; then compound 1; then compound 4.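

In this assay, among the compounds shown here, hydrogen in place of carboxy on this aromatic carbon, ortho to a hydroxy group, gives a 25-fold higher number from compound 2 to compound 4 (1.39 log units; beyond the scatter), the first step that changes one place only. Keeping the hydroxy group and the benzyl-bearing thiourea does not preserve the number of compound 2, so within this pair the large change goes with the carboxy group. The number for compound 4 coincides with the figure at which compound 3 is known only as a limit: the limit of >= 200000 nM in this assay, at which 1 of the 4 values shown sits.

The compounds shown leave open whether another group on this aromatic carbon, such as a methyl ester or a primary amide, would hold the number of compound 2. Going by these compounds, what the hydroxy group contributes while the carboxy group stays in place also remains open.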